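The compounds below may be only part of what the source reports. "The series", "measured", "known", "first", "only" and "open" are said of these compounds alone.

Measured so far:
- compound 1, `Cn1cc(-c2ccccc2F)c2cc(C(=O)NCc3ccc(C(=O)Nc4ccccc4N)cc3)[nH]c2c1=O`: 230 nM
- compound 2, `CC(C)Oc1ccccc1-c1cn(C)c(=O)c2[nH]c(C(=O)NCc3ccc(C(=O)Nc4ccccc4N)cc3)cc12`: 130 nM

In a functional assay on MV4-11 cells (Homo sapiens) for antiproliferative activity, read by CCK-8 assay, with a stated time of 72 h (a higher number here means a weaker inhibitor, a lower number a stronger inhibitor), compound 1 gives 230 nM and compound 2 gives 130 nM. The one step between them, a 1.8-fold lower number from compound 1 to compound 2 (0.25 log units; within the scatter), lies within the scatter, so the two numbers cannot be told apart with confidence, and compound 2 simply has the lower of the two numbers shown, with compound 1 its nearest neighbour.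

Compound 3, `Cn1cc(-c2cccc(Cl)c2)c2cc(C(=O)NCc3ccc(C(=O)Nc4ccccc4N)cc3)[nH]c2c1=O`, is not yet measured. It differs from compound 2 in one place: 3-chlorophenyl in place of 2-isopropoxyphenyl on an aromatic carbon. For the measured compounds named here, the only measured step changes the same ring position, from fluoro to isopropoxy, and it stays within the scatter. Going by the values given here, no measured step covers the move to a 3-chlorophenyl group, so there is no direct guide. Given that the one available change at this position, a 1.8-fold lower number from compound 1 to compound 2 (0.25 log units; within the scatter), made no difference beyond the scatter, compound 3 is expected to land close to compound 2, with a 1.4-fold higher number from compound 2 to compound 3 (0.14 log units; within the scatter) as the expected step. The estimate for compound 3 in this assay is 180 nM, with a range from 70 nM to 450 nM.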

Compound 3, half-maximal inhibitory concentration: 190 nM
Compound 3: middle estimate off by 1.1-fold (0.02 log units), on the low side, within the range that was stated.
By their numbers in this assay, from the lowest: compounds 2, 3 and 1 (each within the scatter of the next).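

In this assay the group on this aromatic carbon has now been exchanged in two further ways: 3-chlorophenyl in place of 2-isopropoxyphenyl gives a 1.5-fold higher number from compound 2 to compound 3 (0.16 log units; within the scatter) and 3-chlorophenyl in place of 2-fluorophenyl gives a 1.2-fold lower number from compound 1 to compound 3 (0.08 log units; within the scatter) as its step. For the compounds shown here, the earlier pair covered only one exchange, whereas all three pairs now lie within the scatter, so 2-fluorophenyl, 2-isopropoxyphenyl and 3-chlorophenyl cannot be told apart at this position, even though the group that leaves in the step to compound 3 has 10 heavy atoms and the one that enters has 7. No measurement of any other kind is at hand that could explain this flat picture.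

The compounds shown leave open whether a group without a phenyl ring on this carbon, such as an amine or a carboxylic acid, would give a number beyond the scatter. Going by these compounds alone, they also leave open whether 2-chlorophenyl would read like 3-chlorophenyl, since no two compounds here carry the same substituent at different places on the phenyl ring.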